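The source may report more compounds than this note shows. Statements on the series, on what has been measured and on what is new or still open speak of the compounds shown alone.

The measured compounds, each with its reading in a functional assay on A549 cells (Homo sapiens) for antiproliferative activity, read by MTT assay, with a stated time of 72 h; a higher number here means a weaker inhibitor, a lower number a stronger inhibitor:

compound 1 `O=C(Nc1cccc(F)c1)C(Cl)Cl` – "not determined" (no result reported)
compound 2 `O=C(Nc1cccc(Br)c1)C(Cl)Cl` – 7800 nM
compound 3 `N#Cc1cccc(NC(=O)C(Cl)Cl)c1` – 66500 nM

All three share the same dichloroacetamide core joined to a benzene ring that carries one substituent. Compound 1 has no number to place it. Between the two that do, compound 3 stands at the higher end: the step of an 8.5-fold higher number from compound 2 to compound 3 (0.93 log units; beyond the scatter) shows that swapping bromo for cyano on the ring made the inhibitor weaker by a clear margin.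

Compound 4 `O=C(Nc1cccc([N+](=O)[O-])c1)C(Cl)Cl` is the next variation on the same ring position. Relative to compound 3 the change is nitro in place of cyano on an aromatic carbon. Within the data shown here, no measured pair covers a swap between cyano and nitro, so the only guide is that one change at this ring position, from bromo to cyano, moved this assay by a modest amount, and that both cyano and nitro are small groups without ring or charge. An exchange between two such groups is expected to produce at most a small step in this assay, in no firmly predictable direction, and quite possibly nothing beyond the scatter.

The expected step of a 1.3-fold lower number from compound 3 to compound 4 (0.12 log units; within the scatter) is therefore close to flat. Compound 4 is estimated at 50000 nM, with a likely range from 12000 nM to 200000 nM.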

Compound 4, half-maximal inhibitory concentration: 18000 nM
The estimate for compound 4 lay 2.8-fold (0.44 log units) above the measured number; the range from low to high includes it.
By their numbers in this assay, from the lowest: compound 2; then compound 4; then compound 3.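

Exchanging two groups that both lack a ring and a charge is not neutral at this place on the ring: in this assay, putting nitro in place of cyano gives a 3.7-fold lower number from compound 3 to compound 4 (0.57 log units; beyond the scatter), so this position distinguishes even between these two groups. The gain does not fully reach the level of the bromo compound, as a 2.3-fold higher number from compound 2 to compound 4 (0.36 log units; beyond the scatter) shows, which gives the three measured groups a clear order in this assay: bromo gives the lowest number, nitro the next and cyano the highest. Nothing measured on these compounds accounts for that order, which therefore stands as an observation without an explanation.

The compounds shown leave open where a quite different group, such as an amine, a carboxylic acid or a longer chain, would fall in this order when placed on the same ring carbon. They also leave open whether bromo, nitro and cyano would keep the same order on another carbon of the ring, or with a change elsewhere in the shared core.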